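Moving the fluoro group: from compound 3 to compound 4

This account rests on a few compounds, and the source may have more. Where it says the series, first, only, none or still open, it means among the compounds named here.

compound 1 `CN1CC[C@H](c2c(O)cc(O)c3c(=O)cc(/C=C/c4ccc(Cl)cc4)oc23)[C@H](O)C1`: 49000 nM
compound 2 `CN1CC[C@H](c2c(O)cc(O)c3c(=O)cc(/C=C/c4cccc(Cl)c4)oc23)[C@H](O)C1`: 2000 nM
compound 3 `CN1CC[C@H](c2c(O)cc(O)c3c(=O)cc(/C=C/c4cccc(F)c4)oc23)[C@H](O)C1`: 3000 nM

These values all come from a functional assay on MCF7 cells (Homo sapiens) for inhibition, read by MTT assay, with a stated time of 48 h; on this read-out lower numbers stand for stronger inhibition of growth and higher numbers for weaker inhibition of growth. The data show a 1.5-fold higher number from compound 2 to compound 3 (0.18 log units; within the scatter), so those two cannot be told apart, while they also show a 16-fold lower number from compound 1 to compound 3 (1.21 log units; beyond the scatter), a clear gap. The next compound, compound 4 `CN1CC[C@H](c2c(O)cc(O)c3c(=O)cc(/C=C/c4ccccc4F)oc23)[C@H](O)C1`, keeps the shared core and changes one group: 2-fluorophenyl in place of 3-fluorophenyl on a double-bonded chain carbon bound to a double-bonded chain carbon. In words, 2-fluorophenyl stands in place of 3-fluorophenyl.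

Going by the values given here, no measured step shows this exact change. The closest evidence is a 25-fold lower number from compound 1 to compound 2 (1.39 log units; beyond the scatter), where 3-chlorophenyl replaces 4-chlorophenyl, so swapping one such group for another can count heavily in this small set. Among the compounds with values here, only that single comparison exists, and it says nothing directly about 2-fluorophenyl. A modest move toward a higher number is therefore expected, with wide uncertainty. The expected change is a 1.7-fold higher number from compound 3 to compound 4 (0.22 log units; within the scatter). For compound 4 the estimate is 5000 nM, with an expected range of 1500 nM to 25000 nM.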

Compound 4, concentration for 50% growth inhibition: 8000 nM
Estimate against measurement, compound 4: 1.6-fold (0.20 log units) below; the range from low to high includes it.
By their numbers in this assay, from the lowest: compounds 2 and 3 (each within the scatter of the next); then compound 4; then compound 1.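

In this assay the place of the fluoro group on the phenyl ring matters: a 2.7-fold higher number from compound 3 to compound 4 (0.43 log units; beyond the scatter) is a step beyond the scatter, and the two compounds hold the same atoms, joined differently. Compound 4 also sits in the middle of the set, with a 4.0-fold higher number from compound 2 to compound 4 (0.60 log units; beyond the scatter) on one side and a 6.1-fold lower number from compound 1 to compound 4 (0.79 log units; beyond the scatter) on the other, so the 2-fluorophenyl group gives a result unlike either the 3-halophenyl pair or the 4-chlorophenyl group. Nothing measured here explains why the 2-fluorophenyl and 3-fluorophenyl groups differ.

Still open, from the compounds shown here alone, is whether 4-fluorophenyl would give a number as high as 4-chlorophenyl does, and whether 2-chlorophenyl would stand close to 2-fluorophenyl. Also open, going by these compounds, is how a methoxy group or an amine on the same phenyl ring would compare.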